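A Bulkier Aromatic Group on the Ring Nitrogen

This account rests on a few compounds, and the source may have more. Where it says the series, first, only, none or still open, it means among the compounds named here.

Compound 1 `C/C(=C\CC/C(C)=C/CC[C@@H]1[C@@]2(C)CCC(=O)C(C)(C)[C@H]2CC[C@@]1(C)O)CC/C=C(\C)C(=O)OCc1cn(C[C@@H]2O[C@H](n3ccc(=O)[nH]c3=O)C[C@H]2O)nn1`: 148000 nM
Compound 2 `C/C(=C\CC/C(C)=C/CC[C@@H]1[C@@]2(C)CCC(=O)C(C)(C)[C@H]2CC[C@@]1(C)O)CC/C=C(\C)C(=O)OCc1cn(-c2cccc(C)c2)nn1`: > 150000 nM
Compound 3 `C/C(=C\CC/C(C)=C/CC[C@@H]1[C@@]2(C)CCC(=O)C(C)(C)[C@H]2CC[C@@]1(C)O)CC/C=C(\C)C(=O)OCc1cn([C@@H]2C[C@@H](n3cc(C)c(=O)[nH]c3=O)O[C@H]2CO)nn1`: 115000 nM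

In an ADME assay on L132 cells (Homo sapiens) for cytotoxicity, read by MTT assay, with a stated time of 48 h (a lower number here means a stronger inhibitor, a higher number a weaker inhibitor), compound 1 gives 148000 nM and compound 3 gives 115000 nM. For compound 2 the assay reports only a limit, > 150000 nM, so compound 2 stands at the weak end of what has been measured; it sits at the limit of > 150000 nM in this assay, at which 1 of the 3 values shown sits. Compound 4 `C/C(=C\CC/C(C)=C/CC[C@@H]1[C@@]2(C)CCC(=O)C(C)(C)[C@H]2CC[C@@]1(C)O)CC/C=C(\C)C(=O)OCc1cn(-c2ccc(C(C)(C)C)cc2)nn1` differs from compound 2 in one place: 4-(tert-butyl)phenyl in place of 3-methylphenyl on an aromatic nitrogen. Going by the values given here, no measured pair differs in a single place, so there is no measured step to lean on. The change is expected to bring no shift beyond the usual scatter, a step that the limit leaves unreadable from compound 2 to compound 4. For compound 4 the expected value is 160000 nM, within 90000 nM to 300000 nM, and a limit rather than a number is quite possible.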

Compound 4, half-maximal inhibitory concentration: 65800 nM
Beside the measured number, compound 4's estimate is 2.4-fold (0.39 log units) above it, and the stated range ends above it.
By their numbers in this assay, from the lowest: compounds 4, 3 and 1 (each within the scatter of the next, the first and the last beyond it). At a limit, above all of these: compound 2.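

In this assay, putting 4-(tert-butyl)phenyl in place of 3-methylphenyl on the aromatic nitrogen gives an at least 2.2-fold lower number from compound 2 to compound 4 (0.35 log units; beyond the scatter). Going by these compounds alone, this is the first single-place change, and it shows that the group on this nitrogen can alter the read-out. The size of the step remains a minimum because compound 2 is recorded only as a limit: the limit of > 150000 nM in this assay, at which 1 of the 4 values shown sits.

The compounds shown leave open what a 4-methylphenyl or 4-aminophenyl group would do on this nitrogen. Either one would help show how much of the step belongs to the tert-butyl group itself.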